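Halogen for nitro on the pendant aryl ring

A few compounds are considered here, and "the series" means these few. Any claim that something is new, unique, unknown or untested is made for them only; others in the source may bear on it.

Compound 1 `COc1cc2c(cc1OC)C(c1ccc([N+](=O)[O-])cc1)=NN=C(S)C2` is the nitro-bearing member of the series. In a functional assay on the whole organism with Mus musculus as the target, in the rotarod test (a lower number here means that less compound is needed, a higher number that more compound is needed for the effect), compound 1 gives only a limit, > 150 umol/kg, and no number. Among the compounds with values here, that limit, (the limit of > 150 umol/kg in this assay, at which 1 of the 2 values shown sits), is all that fixes where compound 1 stands, so no measured step can start from it. Compound 2 `COc1cc2c(cc1OC)C(c1ccc(Br)cc1)=NNC(=O)C2` carries a bromo group and a carbonyl in place of the thione; in this assay compound 2 gives 226 umol/kg. Compound 2 differs from compound 1 in more than one place. Within the data shown here, no step between them is read, and nothing more is drawn from the pair.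

Compound 3 `COc1cc2c(cc1OC)C(c1ccc(Cl)cc1)=NN=C(S)C2` is the next member to be tested. It differs from compound 1 in one place: chloro in place of nitro on an aromatic carbon. Since compound 1 is known only as a limit, the step to compound 3 cannot be sized from measurement; the expectation is a step that the limit leaves unreadable from compound 1 to compound 3 no larger than the scatter, with compound 3 expected near the limit rather than far from it. Compound 3 is expected to give 200 umol/kg, with a range from 80 umol/kg to 500 umol/kg, and a fair chance that this assay again reports only a limit.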

Compound 3, dose for half-maximal effect: 193 umol/kg
The estimate for compound 3 lay 1.0-fold (0.02 log units) above the measured number; low and high end bracket the measured number.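

The step from compound 1 to compound 3, chloro in place of nitro on an aromatic carbon, cannot be read in this assay, because compound 1 is fixed only by a limit: the limit of > 150 umol/kg in this assay, at which 1 of the 3 values shown sits. Left open is whether this exchange changes the dose needed at all, and how thione and carbonyl compare with the same group on the pendant ring.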